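Adding a chloro group to compound 3

The source may hold more compounds than are shown below. What is called first, only, known or untested is meant among the compounds shown, and "the series" means these compounds.

Values in a functional assay on OVCAR-8 cells (Homo sapiens) for inhibition, read by sulforhodamine B assay, with a stated time of 48 h; on this read-out higher numbers stand for weaker inhibition of growth and lower numbers for stronger inhibition of growth:
Compound 1 `CN(C)/C=C/C(=O)c1nn(-c2ccccc2)c(-c2ccccc2)c1C#N`: 75800 nM
Compound 2 `Cc1nnc(-c2nn(-c3ccccc3)c(-c3ccccc3)c2C#N)c2cn(-c3ccccc3)nc12`: > 100000 nM, a limit of the assay
Compound 3 `N#Cc1c(-c2nnc(O)c3nn(-c4ccccc4)cc23)nn(-c2ccccc2)c1-c1ccccc1`: 61500 nM

Compound 3 and compound 1 lie within the usual scatter of each other, so these numbers do not separate them. Compound 2 gives only a limit and no number.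

Compound 4 `N#Cc1c(-c2nnc(O)c3nn(-c4ccc(Cl)cc4)cc23)nn(-c2ccccc2)c1-c1ccccc1` differs from compound 3 by a single change, chloro in place of hydrogen on an aromatic carbon, which turns a phenyl into a 4-chlorophenyl: chloro in place of hydrogen on an aromatic carbon. Among the compounds with values here, the only measured step, an at least 1.6-fold lower number from compound 2 to compound 3 (0.21 log units; that floor lies within the scatter), swaps a different pair of groups, so it says little about chloro. Within the data shown here, no measured pair shows this change.

The expectation therefore starts from compound 3 at 61500 nM, and no step beyond the scatter is expected in this assay. The estimated step is a 1.2-fold lower number from compound 3 to compound 4 (0.07 log units; within the scatter).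

For compound 4 the expected value is 52000 nM, with an estimated range from 20000 nM to 100000 nM.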

Compound 4, concentration for 50% growth inhibition: 3230 nM
The estimate for compound 4 lay 16-fold (1.21 log units) above the measured number, and the stated range ends above it.
By their numbers in this assay, from the lowest: compound 4; then compounds 3 and 1 (each within the scatter of the next). At a limit, above all of these: compound 2.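

In this assay, the phenyl that becomes a 4-chlorophenyl proves to be a place where one added chlorine atom can shift the read-out strongly: the change gives a 19-fold lower number from compound 3 to compound 4 (1.28 log units; beyond the scatter). The only earlier step had a floor within the usual scatter, so this is the first clear sign among these compounds that a small change to the core's substituents can alter growth inhibition. Nothing in the data shown explains why this one atom has so large an effect.

A single pair cannot show whether the effect is specific to chloro or would also appear with fluoro, methoxy or an amine at the same place. It also leaves open whether chloro on the other phenyl groups of compound 4 would give a comparable step.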